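A few compounds are considered here, and "the series" means these few. Any claim that something is new, unique, unknown or untested is made for them only; others in the source may bear on it.

Working notes on the series, all read in a functional assay on SW-620 cells (Homo sapiens) for cytotoxicity, read by sulforhodamine B assay, with a stated time of 48 h; on this read-out higher numbers stand for weaker inhibition and lower numbers for stronger inhibition. Compound 1 `C[C@H]1CC[C@@H]2[C@@H](OC(=O)[C@]23CC(c2ccc(O)cc2)=NO3)[C@]2(C)C(=O)C=C[C@@]12O` gives 89000 nM, compound 2 `COc1cc(C2=NO[C@]3(C2)C(=O)O[C@@H]2[C@H]3CC[C@H](C)[C@]3(O)C=CC(=O)[C@@]23C)ccc1O` gives 88000 nM, and compound 3 `Cc1ccccc1C1=NO[C@]2(C1)C(=O)O[C@@H]1[C@H]2CC[C@H](C)[C@]2(O)C=CC(=O)[C@@]12C` gives 5000 nM, the lowest of the three numbers. Compound 4 `C[C@H]1CC[C@@H]2[C@@H](OC(=O)[C@]23CC(c2ccc(F)cc2)=NO3)[C@]2(C)C(=O)C=C[C@@]12O` is the next to be read: 4-fluorophenyl in place of 2-methylphenyl on a carbon with a double bond to nitrogen. In words, it carries 4-fluorophenyl in place of 2-methylphenyl on a carbon with a double bond to nitrogen.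

Going by the values given here, two measured steps bear most directly on this change: an 18-fold lower number from compound 1 to compound 3 (1.25 log units; beyond the scatter) and an 18-fold lower number from compound 2 to compound 3 (1.25 log units; beyond the scatter). Both end at 2-methylphenyl, one starting from 4-hydroxyphenyl and the other from 4-hydroxy-3-methoxyphenyl. A third, a 1.0-fold lower number from compound 1 to compound 2 (0.00 log units; within the scatter), shows no separation between those two starting points. Among the compounds with values here, no measured compound carries 4-fluorophenyl, and these data cannot separate the loss of hydroxy from the arrival of 2-methylphenyl. Compound 4 lacks both groups, so a moderate move toward higher numbers is expected in this assay. The expected step is a 3.0-fold higher number from compound 3 to compound 4 (0.48 log units; beyond the scatter). For compound 4 the estimated value is 15000 nM, with an expected range of 4000 nM to 60000 nM.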

Compound 4, half-maximal inhibitory concentration: 3600 nM
Compound 4: the middle estimate sits 4.2-fold (0.62 log units) above what was measured; measured number outside the range, below it.
By their numbers in this assay, from the lowest: compounds 4 and 3 (each within the scatter of the next); then compounds 2 and 1 (each within the scatter of the next).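

In this assay, the carbon with a double bond to nitrogen now carries two different aryl groups without hydroxy, and they do not separate, with a 1.4-fold lower number from compound 3 to compound 4 (0.14 log units; within the scatter) within the scatter. Going by these compounds alone, the direct exchange on the aromatic carbon gives a 25-fold lower number from compound 1 to compound 4 (1.39 log units; beyond the scatter), and the change from 4-hydroxy-3-methoxyphenyl gives a 24-fold lower number from compound 2 to compound 4 (1.39 log units; beyond the scatter), so across these four compounds the lower numbers do not depend on 2-methylphenyl and both aryl groups without hydroxy go with them, with no compound going against this. Nothing measured here gives a reason for this separation.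

On these data alone, whether plain phenyl would fall with compound 3 and compound 4 remains open. Also open, as far as these compounds go, is how an aromatic ring bearing an amine or a carboxylic acid would read at this position.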